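A few compounds are considered here, and "the series" means these few. Any claim that something is new, unique, unknown or untested is made for them only; others in the source may bear on it.

Among the compounds with values here, in an assay on LtK cells with ATP-sensitive inward rectifier potassium channel 11 (Homo sapiens) as the target (a higher number here means that more compound is needed for the effect, a lower number that less compound is needed), compound 3 `O=C(Nc1c(C(O)(C(F)(F)F)C(F)(F)F)ccc2ccccc12)c1cccc(Br)c1` gives 80 nM, which places it second highest of the three numbers measured so far. Compound 1 `C/C=C/C(=O)Nc1c(C(O)(C(F)(F)F)C(F)(F)F)ccc2ccccc12` gives 72 nM, and compound 2 `CC(C)OC(=O)Nc1c(C(O)(C(F)(F)F)C(F)(F)F)ccc2ccccc12` gives 1160 nM. The step of a 1.1-fold higher number from compound 1 to compound 3 (0.05 log units; within the scatter) shows that replacing the chain on the carbonyl carbon with a substituted aromatic ring left the number within the scatter, whereas a 16-fold higher number from compound 1 to compound 2 (1.21 log units; beyond the scatter) and a 15-fold lower number from compound 2 to compound 3 (1.16 log units; beyond the scatter) were large. Compound 4 `O=C(Nc1c(C(O)(C(F)(F)F)C(F)(F)F)ccc2ccccc12)c1ccc(OC(F)(F)F)cc1` carries 4-(trifluoromethoxy)phenyl in place of 3-bromophenyl on a carbonyl carbon. Within the data shown here, no measured step exchanges one substituted aromatic ring for another, so the nearest guide is the small move from compound 1 to compound 3; a step of about a 1.1-fold higher number from compound 3 to compound 4 (0.05 log units; within the scatter) is therefore expected, nothing beyond the scatter. Compound 4 is estimated at 90 nM, within a range of 30 nM to 300 nM.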

Compound 4, half-maximal effective concentration: > 10000 nM
Compound 4 was reported as a limit; the forecaster's own chance of this, stated with the estimate: 3%; at least 110-fold (2.04 log units) between middle value and limit.
By their numbers in this assay, from the lowest: compounds 1 and 3 (each within the scatter of the next); then compound 2. At a limit, above all of these: compound 4.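

Swapping the group on this carbonyl carbon is not always tolerated: 3-bromophenyl matched prop-1-en-1-yl, but 4-(trifluoromethoxy)phenyl brings an at least 120-fold higher number from compound 3 to compound 4 (2.09 log units; beyond the scatter) and an at least 130-fold higher number from compound 1 to compound 4 (2.14 log units; beyond the scatter). Even the isopropoxy carbamate is outdone, with an at least 8.6-fold higher number from compound 2 to compound 4 (0.93 log units; beyond the scatter). The reading for compound 4 is a limit of the assay, not a number: the limit of > 10000 nM in this assay, at which 1 of the 4 values shown sits.

From the compounds shown here alone, it remains open whether the trifluoromethoxy group itself or its place on the ring drives this rise. How a plain phenyl or a methoxy-bearing phenyl would read here also stays unresolved.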